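A few compounds are considered here, and "the series" means these few. Any claim that something is new, unique, unknown or untested is made for them only; others in the source may bear on it.

Measured so far: compound 1 `COc1ccc(-c2cc(=O)c3c(OC)cc(OC)cc3n2C)cc1`, compound 2 `COc1ccc(-c2cc(=O)c3c(OC)cc(OC)cc3n2Cc2ccccc2)cc1`, compound 3 `COc1ccc(-c2cc(=O)c3c(OC)cc(OC)cc3n2S(=O)(=O)c2ccc(C=O)cc2)cc1`.

In an ADME assay on BJ cells (Homo sapiens) for antiproliferative activity, with a stated time of 72 h (on this read-out higher numbers stand for an effect only at larger amounts of compound and lower numbers for an effect already at smaller amounts), compound 1 gives 68000 nM. Compound 2 reaches only a limit of the assay, > 34400 nM. Compound 3 likewise stops at a limit, > 34400 nM. Among the measured compounds shown here, compound 3 thus stands at the limit of > 34400 nM in this assay, at which 2 of the 3 values shown sit, with compound 1 providing the only read number. Compound 4 `COc1ccc(-c2cc(=O)c3c(OC)cc(OC)cc3n2S(=O)(=O)c2cccc([N+](=O)[O-])c2)cc1` differs from compound 3 by 3-nitrophenyl in place of 4-formylphenyl on a sulfonyl sulfur. The steps a step that the limit leaves unreadable from compound 1 to compound 2, a step that the limit leaves unreadable from compound 1 to compound 3 and a step that the two limits leave unreadable from compound 2 to compound 3 are all left unreadable by the limits, so the changes on the aromatic nitrogen give no measured size to lean on. Compound 3 sits at a limit, and compound 4 is expected to stay near that limit, so the step that the limit leaves unreadable from compound 3 to compound 4 is estimated to be small. Compound 4 is accordingly estimated at 50000 nM, between 20000 nM and 150000 nM.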

Compound 4, half-maximal effective concentration: > 39600 nM
Compound 4 was reported as a limit; the forecaster's own chance of this, stated with the estimate: 70%; the middle value lies beyond the limit too.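

Compound 3 gives only a limit of the assay, > 34400 nM. Among the compounds shown here, compound 4 also gives only a limit, > 39600 nM, so no step between these two compounds can be read. The compounds shown leave open whether any group on the sulfonyl sulfur changes the antiproliferative effect at all.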